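Butoxy for butylamino: expected cytotoxicity of compound 4

The compounds below may be only part of what the source reports. "The series", "measured", "known", "first", "only" and "open" are said of these compounds alone.

Compound 3 `CCCCNc1nc(N)nc2c1ncn2/C=C1/CC1(CO)CO` stands at a limit of an ADME assay on HFF cells (Homo sapiens) for cytotoxicity, with a stated time of 8 days; on this read-out lower numbers stand for higher toxicity in this test and higher numbers for lower toxicity in this test: in this assay compound 3 gives > 300000 nM, a limit rather than a number. Compound 1 `CC(C)CSc1nc(N)nc2c1ncn2/C=C1/CC1(CO)CO` likewise gives a limit of > 300000 nM in this assay. Compound 2 `CCCCCOc1nc(N)nc2c1ncn2/C=C1/CC1(CO)CO` gives 259000 nM in this assay. That number lies close to where the other two compounds stand, as shown by the limit of > 300000 nM in this assay, at which 2 of the 3 values shown sit. Compound 4 `CCCCOc1nc(N)nc2c1ncn2/C=C1/CC1(CO)CO` differs from compound 3 by butoxy in place of butylamino on an aromatic carbon. For the measured compounds named here, the one measured step of a related kind is an at least 1.1-fold higher number from compound 2 to compound 3 (0.06 log units; that floor lies within the scatter), whose true size stays hidden behind the limit. The exchange of butylamino for butoxy is therefore expected to leave the read-out near that limit, with no step beyond the scatter. Compound 4 is expected to give about 280000 nM. Its range is estimated from 150000 nM to 600000 nM. This estimate means an at least 1.0-fold lower number from compound 3 to compound 4 (0.02 log units; that floor lies within the scatter), expected to lie within the scatter.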

Compound 4, half-maximal cytotoxic concentration: > 300000 nM
Compound 4 gave a limit, no number; the forecaster's own chance of this, stated with the estimate: 55%; middle value at least 1.0-fold (0.02 log units) from the limit.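

With butoxy on this aromatic carbon, compound 4 also ends at a limit in this assay, so a chain joined through oxygen can reach that limit too, which compound 2 with pentyloxy had not shown: the limit of > 300000 nM in this assay, at which 3 of the 4 values shown sit.

The change from pentyloxy to butoxy is an at least 1.1-fold higher number from compound 2 to compound 4 (0.06 log units; that floor lies within the scatter). The steps to compound 4 from compound 1 and from compound 3 join two limits and cannot be read.

The true values of compound 1, compound 3 and compound 4 stay hidden, so isobutylsulfanyl, butylamino and butoxy cannot be ranked. From the compounds shown here alone, whether a longer chain such as hexyloxy, or benzyloxy, would bring the number down stays open.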